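Aryl ether branching on the compound 1 scaffold

A few compounds are considered here, and "the series" means these few. Any claim that something is new, unique, unknown or untested is made for them only; others in the source may bear on it.

Compound 1 `CCOc1cc(C(=O)N(C)C)ccc1Nc1nc(O[C@H]2CC[C@@](C)(O)CC2)c2cc[nH]c2n1` is the anchor of the set. In a functional assay on CAL-51 cells (Homo sapiens) for antiproliferative activity, read by luminescence and CellTiter-Glo, with a stated time of 3 days (on this read-out higher numbers stand for weaker inhibition and lower numbers for stronger inhibition), compound 1 gives 26 nM, the lowest of the three numbers measured. Going by the values given here, compound 2 `COc1cc(C(=O)N(C)C)ccc1Nc1nc(OC2CCCC2)c2cc[nH]c2n1` gives 497 nM and compound 3 `COc1cc(C(=O)N(C)C)ccc1Nc1nc(OC2CCOCC2)c2cc[nH]c2n1` gives 198 nM; each differs from compound 1 in more than one place, so their numbers show only that compound 1 stands well ahead of both. Among the compounds with values here, the single one-point step measured, a 2.5-fold lower number from compound 2 to compound 3 (0.40 log units; beyond the scatter), concerns the other ether group on the shared core and does not touch the change considered here.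

Compound 4 `C[C@@H](Oc1cc(C(=O)N(C)C)ccc1Nc1nc(O[C@H]2CC[C@@](C)(O)CC2)c2cc[nH]c2n1)C(F)(F)F` is obtained from compound 1 by trifluoromethyl in place of hydrogen on a saturated chain carbon bound to an oxygen on an aromatic ring and a saturated chain carbon. Within the data shown here, no measured step bears on this change, so there is nothing to set an expected size or direction from; a step no larger than the usual scatter is expected, with the range widened to reflect the absence of precedent. For compound 4 the estimate is 30 nM (from 10 nM to 100 nM), which is expected to mean a 1.2-fold higher number from compound 1 to compound 4 (0.06 log units; within the scatter).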

Compound 4, half-maximal inhibitory concentration: 24 nM
Compound 4: middle estimate off by 1.3-fold (0.10 log units), on the high side; low and high end bracket the measured number.
By their numbers in this assay, from the lowest: compounds 4 and 1 (each within the scatter of the next); then compound 3; then compound 2.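

In this assay the change to 1-(trifluoromethyl)ethoxy gives a 1.1-fold lower number from compound 1 to compound 4 (0.03 log units; within the scatter) and so keeps the two numbers within the scatter of each other, even with 4 heavy atoms entering on this saturated chain carbon. Going by these compounds alone, the only earlier one-place step, a 2.5-fold lower number from compound 2 to compound 3 (0.40 log units; beyond the scatter) concerned the other ether group, so this is the sole reading at this position, and it shows that the position accepts trifluoromethyl in place of hydrogen with no step beyond the scatter. No supporting measurement bears on why the two numbers lie so close.

On these data alone, whether the same holds for a plain methyl on this carbon, for the opposite arrangement at this carbon, or for a longer chain such as propyl remains open. The compounds shown also leave open how trifluoromethyl behaves on the chain of the other ether group on the shared core.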